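The source may report more compounds than this note shows. Statements on the series, on what has been measured and on what is new or still open speak of the compounds shown alone.

The measured compounds so far:
compound 1 `c1ccc(-c2noc(-c3ccncc3)n2)cc1` with 657000 nM
compound 2 `COc1ccc(-c2noc(-c3ccc(F)cc3)n2)cc1O` with > 1000000 nM
compound 3 `COc1ccc(-c2noc(-c3cccnc3)n2)cc1OC1CCCC1` with > 1000000 nM

For the measured compounds named here, in a functional assay on DU-145 cells (Homo sapiens) for antiproliferative activity, read by MTT assay, with a stated time of 24 h (a lower number here means a stronger inhibitor, a higher number a weaker inhibitor), compound 1 gives 657000 nM, the only plain number in the set. Compound 2 reaches only the limit of the assay, > 1000000 nM. Compound 3 likewise stops at the limit, > 1000000 nM. Compound 3 therefore stands at the limit of > 1000000 nM in this assay, at which 2 of the 3 values shown sit, and no ordering of compound 3 against compound 2 can be read from the values, both being limits.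

Compound 4 `COc1ccc(-c2noc(-c3ccc(F)cc3)n2)cc1OC1CCCC1` has not been measured. It differs from compound 3 by 4-fluorophenyl in place of pyridin-3-yl on an aromatic carbon. Going by the values given here, no step between two measured compounds is available to weigh this change; compound 2, which also carries 4-fluorophenyl, is itself a limit. In this assay the expected change, an at least 1.1-fold lower number from compound 3 to compound 4 (0.04 log units; that floor lies within the scatter), is none beyond the scatter. Compound 4 is therefore estimated at 900000 nM, with a range from 250000 nM to 3000000 nM, and it is expected that the assay may again report only a limit.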

Compound 4, half-maximal inhibitory concentration: 20700 nM
Estimate against measurement, compound 4: 43-fold (1.64 log units) above, and the stated range ends above it.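

In this assay, the aromatic carbon of the five-membered ring proves sensitive to the group it carries: 4-fluorophenyl in place of pyridin-3-yl gives an at least 48-fold lower number from compound 3 to compound 4 (1.68 log units; beyond the scatter). Neither change is enough alone, as the cyclopentyl on the oxygen also counts, with an at least 48-fold lower number from compound 2 to compound 4 (1.68 log units; beyond the scatter), and only compound 4 combines cyclopentyl with 4-fluorophenyl. Both steps start from a limit, so each gives a floor and not an exact size: the limit of > 1000000 nM in this assay, at which 2 of the 4 values shown sit.

The compounds shown leave open whether a 4-chlorophenyl or a 4-aminophenyl on this carbon would serve as 4-fluorophenyl does, and whether a methyl or a longer chain on the oxygen would serve as cyclopentyl does. Compound 1 differs from compound 4 in more than one place, so it offers no comparison with it.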